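Thiophene exchange on the shared core: cytotoxicity outlook

This account rests on a few compounds, and the source may have more. Where it says the series, first, only, none or still open, it means among the compounds named here.

Three compounds have numbers in an ADME assay on Vero cells (Chlorocebus sabaeus) for cytotoxicity, with a stated time of 5 days; on this read-out lower numbers stand for stronger inhibition and higher numbers for weaker inhibition. Compound 1 `O=C(/C=C/c1ccc(N2CCCCC2)cc1)c1ccsc1` gives 34400 nM, compound 2 `Cc1ccc(C(=O)/C=C/c2ccc(N3CCCCC3)cc2)s1` gives 50500 nM, and compound 3 `Cc1csc(C2=NNC(c3ccc(N4CCCCC4)cc3)C2)c1` gives 31600 nM. All three lie within the scatter of one another, compound 3 sitting nearest to compound 1 and furthest from compound 2. Compound 4 `Clc1cc(C2=NNC(c3ccc(N4CCCCC4)cc3)C2)c(Cl)s1` differs from compound 3 by 2,5-dichlorothiophen-3-yl in place of 4-methylthiophen-2-yl on a carbon with a double bond to nitrogen. Going by the values given here, the only measured step that exchanges one thiophene for another is a 1.5-fold higher number from compound 1 to compound 2 (0.17 log units; within the scatter), which stayed within the scatter and sits at a different place on the core. Among the compounds with values here, the 2,5-dichlorothiophen-3-yl group has no precedent among the measured compounds. On this basis no change beyond the scatter is expected, meaning a 1.1-fold higher number from compound 3 to compound 4 (0.04 log units; within the scatter). Compound 4 is estimated at 35000 nM, with a range from 12000 nM to 100000 nM.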

Compound 4, half-maximal inhibitory concentration: 53900 nM
Beside the measured number, compound 4's estimate is 1.5-fold (0.19 log units) below it, and the stated range covers the measured number.
By their numbers in this assay, from the lowest: compounds 3, 1, 2 and 4 (each within the scatter of the next).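

In this assay, the exchange on the carbon with a double bond to nitrogen gives a 1.7-fold higher number from compound 3 to compound 4 (0.23 log units; within the scatter), so the read-out does not separate these two thiophenes at this place. The change from compound 3 to compound 4 removes the methyl, adds two chlorines and moves the thiophene attachment from the 2-yl to the 3-yl position, and this combined change still stays within the scatter. No supporting data bear on this result.

Which of these changes contributes what remains open, as they occur together here. Also open, as far as these compounds go, is how a carboxylic acid or an amine in place of the thiophene would read in this assay.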